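Fluoro to hydrogen on the benzyloxy ring of compound 2

The compounds below may be only part of what the source reports. "The series", "measured", "known", "first", "only" and "open" are said of these compounds alone.

In an assay on isolated protein for inhibition of prostaglandin E2 receptor EP1 subtype (Homo sapiens) (a higher number here means a weaker inhibitor, a lower number a stronger inhibitor), compound 1 `CSc1ccc(OCc2ccccc2)c(C2=C(c3cccc(C(=O)O)c3)CCC2)c1` gives 63.1 nM. Compound 2 `CS(=O)(=O)c1ccc(OCc2ccc(F)cc2)c(C2=C(c3cccc(C(=O)O)c3)CCC2)c1`, in this assay, gives 79.4 nM, the higher of the two numbers, though the gap to compound 1 sits within the scatter. Compound 3 `CS(=O)(=O)c1ccc(OCc2ccccc2)c(C2=C(c3cccc(C(=O)O)c3)CCC2)c1` differs from compound 2 by hydrogen in place of fluoro on an aromatic carbon. Among the compounds with values here, no step between measured compounds shows what this change does, so no shift beyond the scatter is expected in this assay. The step of a 1.1-fold lower number from compound 2 to compound 3 (0.05 log units; within the scatter) is expected to stay within the scatter. Compound 3 is estimated at 70 nM in this assay, with a range from 30 nM to 160 nM.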

Compound 3, half-maximal inhibitory concentration: 79.4 nM
The estimate for compound 3 lay 1.1-fold (0.05 log units) below the measured number; the measured number falls inside the stated range.
By their numbers in this assay, from the lowest: compounds 1, 2 and 3 (each within the scatter of the next).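

In this assay, (4-fluorobenzyl)oxy to benzyloxy gives no change at the digits printed from compound 2 to compound 3 (within the scatter), so with methylsulfonyl on the core, the fluoro can go without a shift beyond the scatter. Compound 3 also completes a second single-place pair, where methylsulfonyl in place of methylsulfanyl gives a 1.3-fold higher number from compound 1 to compound 3 (0.10 log units; within the scatter), again within the scatter. As far as these compounds go, whether this tolerance extends to larger or different groups on that ring, such as chloro, methoxy or an amine, stays open. No data at hand bear on the reason for these results.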